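The compounds below may be only part of what the source reports. "The series", "measured", "known", "first", "only" and "open" are said of these compounds alone.

Values measured in a functional assay, read by spectrophotometry, tested at 100 uM; on this read-out lower numbers stand for stronger inhibition and higher numbers for weaker inhibition:
- Compound 1 `CN(C)c1ccc(/C=C/C(=O)c2cccc(NC(=O)c3cc(-c4ccncc4)n[nH]3)c2)cc1`: 60900 nM
- Compound 2 `O=C(/C=C/c1ccccc1Cl)c1cccc(NC(=O)c2cc(-c3ccncc3)n[nH]2)c1`: 79800 nM
- Compound 3 `COc1cc(/C=C/C(=O)c2cccc(NC(=O)c3cc(-c4ccncc4)n[nH]3)c2)cc(OC)c1OC`: 52900 nM

Compound 3 gives 52900 nM, a value within the scatter of those of both other compounds, so the three cannot be ranked. Compound 4 `COc1ccccc1/C=C/C(=O)c1cccc(NC(=O)c2cc(-c3ccncc3)n[nH]2)c1` has not yet been measured. In compound 4, 2-methoxyphenyl stands in place of 3,4,5-trimethoxyphenyl on a double-bonded chain carbon bound to a double-bonded chain carbon (2-methoxyphenyl in place of 3,4,5-trimethoxyphenyl on a double-bonded chain carbon bound to a double-bonded chain carbon).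

Going by the values given here, three measured steps bear on this change, each an exchange of the group at that same place. They are a 1.3-fold higher number from compound 1 to compound 2 (0.12 log units; within the scatter), a 1.2-fold lower number from compound 1 to compound 3 (0.06 log units; within the scatter) and a 1.5-fold lower number from compound 2 to compound 3 (0.18 log units; within the scatter). All three stay within the scatter, so no step beyond the scatter is expected in this assay, and no direction can be favoured. The expected step is a 1.1-fold higher number from compound 3 to compound 4 (0.05 log units; within the scatter). Compound 4 is estimated at 60000 nM. The expected range for compound 4 runs from 35000 nM to 100000 nM.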

Compound 4, half-maximal inhibitory concentration: 56700 nM
The estimate for compound 4 lay 1.1-fold (0.02 log units) above the measured number, and the stated range covers the measured number.
By their numbers in this assay, from the lowest: compounds 3, 4, 1 and 2 (each within the scatter of the next).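

In this assay, going from 12 heavy atoms and 3 hydrogen-bond acceptors in 3,4,5-trimethoxyphenyl to 8 heavy atoms and 1 hydrogen-bond acceptor in 2-methoxyphenyl gives values that cannot be told apart (a 1.1-fold higher number from compound 3 to compound 4 (0.03 log units; within the scatter)). The same holds for the direct exchange of chloro for methoxy on an aromatic carbon (a 1.4-fold lower number from compound 2 to compound 4 (0.15 log units; within the scatter)) and for 2-methoxyphenyl in place of 4-(dimethylamino)phenyl (a 1.1-fold lower number from compound 1 to compound 4 (0.03 log units; within the scatter)), so all four substituted phenyl groups at this place, on a double-bonded chain carbon bound to a double-bonded chain carbon, fall within the scatter of one another. No measurement is available that would explain this result.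

From the compounds shown here alone, it remains open whether anything other than a substituted phenyl group at this place, such as a piperidine or a carboxylic acid on a longer chain, would give a value beyond the scatter. Going by these compounds, it is also open whether exchanges on the shared core would do so.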